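Swapping the hydrazone aryl group: compound 3 to compound 4

This account rests on a few compounds, and the source may have more. Where it says the series, first, only, none or still open, it means among the compounds named here.

Three compounds sharing one core were tested in a functional assay on HT-29 cells (Homo sapiens) for cytotoxicity, read by MTT assay, with a stated time of 72 h; on this read-out higher numbers stand for weaker inhibition and lower numbers for stronger inhibition. Compound 1 `CN(C)CCn1cnnc1-c1cc(Oc2ccc(NC(=O)N/N=C/c3c[nH]c4ccccc34)cc2F)ccn1` gives 1300 nM. Compound 2 `COc1ccc(OC)c(/C=N/NC(=O)Nc2ccc(Oc3ccnc(-c4nncn4CCN(C)C)c3)c(F)c2)c1` gives 2070 nM. Compound 3 `COc1ccc(/C=N/NC(=O)Nc2ccc(Oc3ccnc(-c4nncn4CCN(C)C)c3)c(F)c2)c(OC)c1` gives 1780 nM, the second highest of the three numbers, though every gap is within the scatter: a 1.4-fold higher number from compound 1 to compound 3 (0.14 log units; within the scatter) and a 1.2-fold lower number from compound 2 to compound 3 (0.07 log units; within the scatter). Compound 4 `CN(C)CCn1cnnc1-c1cc(Oc2ccc(NC(=O)N/N=C/c3ccc(O)c(Br)c3)cc2F)ccn1` is not yet measured; it differs from compound 3 only at the carbon with a double bond to nitrogen: 3-bromo-4-hydroxyphenyl in place of 2,4-dimethoxyphenyl on a carbon with a double bond to nitrogen. The earlier swaps of the aryl group on that same carbon, including a 1.6-fold higher number from compound 1 to compound 2 (0.20 log units; within the scatter), all stayed within the scatter, so no step beyond the scatter is expected here in either direction. Compound 4 is therefore expected to give about 1800 nM, within a range of 700 nM to 4500 nM, an expected step of a 1.0-fold higher number from compound 3 to compound 4 (0.00 log units; within the scatter).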

Compound 4, half-maximal inhibitory concentration: 450 nM
Compound 4: the middle estimate sits 4.0-fold (0.60 log units) above what was measured, outside the stated range (below it).
By their numbers in this assay, from the lowest: compound 4; then compounds 1, 3 and 2 (each within the scatter of the next).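

The aryl group on the carbon with a double bond to nitrogen can shift the number beyond the scatter after all: 3-bromo-4-hydroxyphenyl gives a 4.0-fold lower number from compound 3 to compound 4 (0.60 log units; beyond the scatter), a 4.6-fold lower number from compound 2 to compound 4 (0.66 log units; beyond the scatter) and a 2.9-fold lower number from compound 1 to compound 4 (0.46 log units; beyond the scatter), whereas swaps among the earlier three groups did not. The bromine and the hydroxyl enter together, so these compounds cannot separate their contributions. Nothing measured here explains the step.

Still open, as far as these compounds go, is how a phenyl group carrying only the hydroxyl or only the bromine would compare. Also open, from the compounds shown here alone, is whether chlorine in place of bromine would keep the step.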